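This account rests on a few compounds, and the source may have more. Where it says the series, first, only, none or still open, it means among the compounds named here.

Compound 3 `O=C1N(Cc2cn(Cc3ccccc3)nn2)c2ccccc2[C@@]1(O)c1ccsc1` in a functional assay on SW480 cells (Homo sapiens) for inhibition, read by MTT assay, with a stated time of 72 h (a higher number here means a weaker inhibitor, a lower number a stronger inhibitor), gives 62500 nM, the highest number among the three measured compounds, though the gap to compound 1 `O=C1C(=O)N(Cc2cn(Cc3ccccc3)nn2)c2ccccc21`, which gives 32200 nM, lies within the scatter, and only the gap to compound 2 `Cc1ccc2c(c1)C(=O)C(=O)N2Cc1cn(Cc2ccccc2)nn1`, which gives 26600 nM, goes beyond it. Going by the values given here, the single step between measured compounds, a 1.2-fold lower number from compound 1 to compound 2 (0.08 log units; within the scatter), concerns a methyl on an aromatic carbon of the shared core and says nothing about the saturated ring carbon that bears the hydroxyl. Compound 4 `O=C1N(Cc2cn(Cc3ccccc3)nn2)c2ccccc2[C@]1(O)c1ccsc1` keeps every atom and bond of compound 3 and differs only in configuration: the two compounds have the same atoms and bonds and differ only in configuration as drawn: 1 of 1 stereo elements differ; a stereocentre at a saturated ring carbon is drawn R in compound 3 and S in compound 4. Among the compounds with values here, no measured step bears on a change of configuration at this centre, so the data give no direction for it. The step from compound 3 to compound 4 is therefore expected to be no change at the digits printed from compound 3 to compound 4 (within the scatter), within the scatter. Compound 4 is estimated to give 62500 nM in this assay, with a range from 20000 nM to 160000 nM.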

Compound 4, half-maximal inhibitory concentration: 29500 nM
Beside the measured number, compound 4's estimate is 2.1-fold (0.33 log units) above it, and the stated range covers the measured number.
By their numbers in this assay, from the lowest: compounds 2, 4, 1 and 3 (each within the scatter of the next, the first and the last beyond it).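

In this assay the saturated ring carbon that bears the hydroxyl turns out to be a position where the drawn configuration alone registers, with a 2.1-fold lower number from compound 3 to compound 4 (0.33 log units; beyond the scatter) as the step, a modest one. The only earlier step, a methyl on an aromatic carbon, stayed within the scatter, so this is the first single change among these compounds that moves the number beyond it. The step can be put down to configuration at this centre and nothing else, because no other feature changes: the fact that compounds 3 and 4 differ only in the configuration as drawn

The compounds shown leave open whether the hydroxyl itself matters at this centre, and whether an amine or a methoxy group in its place would keep the same gap between the two configurations. They also leave open whether that gap would survive with a phenyl ring on this carbon.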